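The source may report more compounds than this note shows. Statements on the series, on what has been measured and on what is new or still open speak of the compounds shown alone.

Measured in a functional assay on NCI-H226 cells (Homo sapiens) for inhibition, read by MTT assay, with a stated time of 48 h, tested at 10 uM; a lower number here means less inhibition, a higher number more inhibition at the concentration tested (going by the name of the read-out):
compound 1 `COc1cc(NC(=O)Nc2cc(Nc3ccc(C(C)(C)C)cc3)ncn2)cc(OC)c1` gives 47.7%
compound 2 `COc1cc(NC(=O)Nc2cc(Nc3cccc(C(C)(C)C)c3)ncn2)cc(OC)c1` gives 40%
compound 3 `COc1cc(NC(=O)Nc2cc(Nc3ccc(C)c(F)c3)ncn2)cc(OC)c1` gives 39.7%

Compound 3 stands lowest of the three, though only within the scatter: its nearest neighbour is compound 2 (a number 0.3 percentage points lower from compound 2 to compound 3 (within the scatter)) and the furthest is compound 1 (a number 8 percentage points lower from compound 1 to compound 3 (within the scatter)). Compound 4 `CCc1cccc(Nc2cc(NC(=O)Nc3cc(OC)cc(OC)c3)ncn2)c1` is the next variation of the same position: 3-ethylphenyl in place of 3-fluoro-4-methylphenyl on a nitrogen on an aromatic ring. Among the compounds with values here, every measured step so far changes the aryl group on that same nitrogen, and none of them moves beyond the scatter: a number 7.7 percentage points lower from compound 1 to compound 2 (within the scatter), a number 8 percentage points lower from compound 1 to compound 3 (within the scatter), a number 0.3 percentage points lower from compound 2 to compound 3 (within the scatter). Compound 4 is therefore expected to behave like the others, with no step beyond the scatter, a number 1.3 percentage points higher from compound 3 to compound 4 (within the scatter). The estimate for compound 4 is 41%, with a range from 28% to 54%.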

Compound 4, a percentage reported as inhibition, at one concentration (the size of the read-out at that concentration, not a potency): 36.7%
The estimate for compound 4 lay 4.3 percentage points above the measured number; the range from low to high includes it.
By their numbers in this assay, from the lowest: compounds 4, 3, 2 and 1 (each within the scatter of the next, the first and the last beyond it).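

In this assay, within the data shown here, the change of aryl group on this nitrogen now gives the first step beyond the scatter, a modest one (a number 11 percentage points lower from compound 1 to compound 4 (beyond the scatter)), with 3-ethylphenyl in place of 4-(tert-butyl)phenyl. The other two new steps stay within the scatter (a number 3 percentage points lower from compound 3 to compound 4 (within the scatter); a number 3.3 percentage points lower from compound 2 to compound 4 (within the scatter)), so 3-ethylphenyl cannot be told apart from 3-fluoro-4-methylphenyl, nor ethyl from tert-butyl on the aromatic carbon. No data at hand bear on what lies behind these steps.

Still open, on these data alone, is whether an aryl group carrying an amine or a carboxylic acid on this nitrogen would shift the number beyond the scatter.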